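The source may hold more compounds than are shown below. What is called first, only, known or untested is meant among the compounds shown, and "the series" means these compounds.

Compound 1 `CCOc1ccccc1-c1ccc(-c2nc3cnccc3c(NC(COC)C(N)=O)c2C#N)cc1` is one of two measured compounds. In a physicochemical assay for lipophilicity, read by HPLC, at pH 7.5 (on this read-out higher numbers stand for higher lipophilicity and lower numbers for lower lipophilicity), compound 1 gives 2.8, the lower of the two numbers. Compound 2 `CC[C@@H](Nc1c(C#N)c(-c2ccc(-c3ccccc3C(C)C)cc2)nc2cnccc12)C(N)=O` in this assay gives 3.5, a reading beyond the usual scatter above that of compound 1. Compound 3 `CCOc1ccccc1-c1ccc(-c2nc3cnccc3c(N[C@H](CC)C(=O)NS(C)(=O)=O)c2C#N)cc1` has not been measured. It differs from compound 1 in one place: a group of 10 heavy atoms (5 carbon, 1 nitrogen, 3 oxygen, 1 sulfur; no ring) in place of a group of 7 heavy atoms (4 carbon, 1 nitrogen, 2 oxygen; no ring), on a nitrogen on an aromatic ring. Going by the values given here, no measured pair shows this change, so the step from compound 1 to compound 3 is estimated rather than known; a downward step of moderate size, a number 1.00 log units lower from compound 1 to compound 3 (beyond the scatter), is expected. Compound 3 is therefore expected to give about 1.8, plausibly between 1 and 2.6.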

Compound 3, distribution coefficient: 2.2
The estimate for compound 3 lay 0.40 log units below the measured number; the range from low to high includes it.
By their numbers in this assay, from the lowest: compound 3; then compound 1; then compound 2.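

In this assay, putting the larger open-chain group bearing sulfur in place of 1-carbamoyl-2-methoxyethyl on the nitrogen gives a number 0.60 log units lower from compound 1 to compound 3 (beyond the scatter) as the first step read at this position. The change therefore moves this read-out, though the two groups differ in more than one feature. No evidence on the reason for this step is available. Going by these compounds alone, the single step does not show which part of the entering group accounts for it. Going by these compounds, how a carboxylic acid or a primary amine in this place would read also remains open.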